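The source may report more compounds than this note shows. Statements on the series, on what has been measured and on what is new or still open speak of the compounds shown alone.

Values in a functional assay on HeLa cells (Homo sapiens) for inhibition, read by sulforhodamine B assay; on this read-out lower numbers stand for stronger inhibition and higher numbers for weaker inhibition:
- compound 1 `O=C1C(Nc2ccc(I)cc2)=CC(=O)c2c1nc1n2[C@H]2OC[C@@H](O)[C@H]2OC1`: 4010 nM
- compound 2 `O=C1C(N2CCCC2)=CC(=O)c2c1nc1n2[C@H]2OC[C@@H](O)[C@H]2OC1`: > 16000 nM (a limit)
- compound 3 `O=C1C=C(Nc2ccc(C(F)(F)F)cc2)C(=O)c2c1nc1n2[C@H]2OC[C@@H](O)[C@H]2OC1`: > 8000 nM (a limit)

Compound 2 stands only at a limit, > 16000 nM. Compound 4 `O=C1C(NCc2ccccc2)=CC(=O)c2c1nc1n2[C@H]2OC[C@@H](O)[C@H]2OC1` carries benzylamino in place of pyrrolidin-1-yl on a double-bonded ring carbon. Within the data shown here, the one measured step that bears on this change is an at least 3.9-fold higher number from compound 1 to compound 2 (0.60 log units; beyond the scatter), which replaces (4-iodophenyl)amino with pyrrolidin-1-yl and lies beyond the scatter. Benzylamino is not the same group as (4-iodophenyl)amino, though both hold an aromatic ring, so only a partial reversal of that step is expected, toward a lower number in this assay. The expected change is an at least 2.2-fold lower number from compound 2 to compound 4 (0.35 log units; beyond the scatter). Compound 4 is estimated at 7000 nM, with an expected range of 2500 nM to 16000 nM.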

Compound 4, half-maximal inhibitory concentration: 11000 nM
Beside the measured number, compound 4's estimate is 1.6-fold (0.20 log units) below it; the measured number falls inside the stated range.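

In this assay, benzylamino in place of pyrrolidin-1-yl gives an at least 1.4-fold lower number from compound 2 to compound 4 (0.16 log units; that floor lies within the scatter), so the size of this change stays unread: the limit of > 16000 nM in this assay, at which 1 of the 4 values shown sits.

The clearer new reading concerns the amine nitrogen, where benzyl in place of 4-iodophenyl gives a 2.7-fold higher number from compound 1 to compound 4 (0.44 log units; beyond the scatter). An aromatic ring in the substituent is therefore not enough on its own to reach the number of compound 1.

Still open, going by these compounds, is whether the iodine or the direct link of the ring to the amine nitrogen accounts for this step; plain phenylamino and 4-chlorophenylamino would help separate the two.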